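Chloro substitution on compound 1: what potency change to expect

The compounds below may be only part of what the source reports. "The series", "measured", "known", "first", "only" and "open" are said of these compounds alone.

Compound 1 `S=C(N/N=C/c1ccccc1)N1CCNCC1` gives 2410 nM in a functional assay on HBL-100 cells (Homo sapiens) for antiproliferative activity, read by MTT assay, with a stated time of 72 h; on this read-out lower numbers stand for stronger inhibition and higher numbers for weaker inhibition.
Compound 2 `C/C(=N\NC(=S)N1CCNCC1)c1ccc(Cl)cc1` gives 260 nM in this assay.
Compound 3 `S=C(NN=C(c1ccccc1)c1ccccc1)N1CCNCC1` gives 340 nM in this assay.

Among these three, compound 1 shows the highest number, meaning the weakest inhibition of cell growth; both compound 2 and compound 3 sit well beyond the usual scatter below it. Compound 4 `S=C(N/N=C/c1ccc(Cl)cc1)N1CCNCC1` differs from compound 1 by chloro in place of hydrogen on an aromatic carbon. Among the measured compounds shown here, no measured pair here isolates exactly that single change, so the step is judged from the wider picture: the chloro-bearing compound 2 lies far below compound 1, though compound 2 also carries a methyl in place of the hydrogen on the imine carbon. A downward step, moderate in size and likely beyond the scatter, is therefore expected from compound 1 to compound 4, a 3.2-fold lower number from compound 1 to compound 4 (0.51 log units; beyond the scatter). Compound 4 is estimated at 750 nM, with a plausible range from 250 nM to 2200 nM.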

Compound 4, half-maximal inhibitory concentration: 1600 nM
Compound 4: middle estimate off by 2.1-fold (0.33 log units), on the low side, within the range that was stated.
By their numbers in this assay, from the lowest: compounds 2 and 3 (each within the scatter of the next); then compounds 4 and 1 (each within the scatter of the next).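

In this assay chloro in place of hydrogen on an aromatic carbon, para to a large group, gives a 1.5-fold lower number from compound 1 to compound 4 (0.18 log units; within the scatter) and so stays within the usual scatter. Among the compounds shown here, this is the first pair to isolate the change, and on the core of compound 1 it shows no clear gain from chloro at this position. Nothing here explains the result.
Still open, from the compounds shown here alone, is whether a methoxy group, an amine or a carboxylic acid at this position would move the number beyond the scatter. Going by these compounds, the effect of chloro elsewhere on the ring also remains open.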